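Swapping a sulfonyl for a carbamate on the piperazine nitrogen

The compounds below may be only part of what the source reports. "The series", "measured", "known", "first", "only" and "open" are said of these compounds alone.

The measured compounds are:
compound 1, `Nc1nc(N2CCN(C(=O)COc3ccc(Cl)cc3)CC2)c2nc(-c3ccc(F)cc3)sc2n1`, 490 nM in a functional assay on cells (Lymphocyte, Homo sapiens); a higher number here means a weaker inhibitor, a lower number a stronger inhibitor;
compound 2, `Cc1cccc(NC(=O)N2CCN(c3nc(N)nc4sc(-c5ccc(F)cc5)nc34)CC2)c1`, 300 nM;
compound 3, `Nc1nc(N2CCN(S(=O)(=O)c3ccccc3)CC2)c2nc(-c3ccc(F)cc3)sc2n1`, for which only a limit is known, > 10000 nM.

Compound 3 thus stands at the weak end of the three: its value is a limit of the assay, not a number, and it sits where the limit of > 10000 nM in this assay, at which 1 of the 3 values shown sits, marks the edge of what was measured. Compounds 1 and 2 both carry a carbonyl on the ring nitrogen, and the two steps leading to compound 3 are both large: an at least 20-fold higher number from compound 1 to compound 3 (1.30 log units; beyond the scatter) and an at least 33-fold higher number from compound 2 to compound 3 (1.52 log units; beyond the scatter). Between compounds 1 and 2 the step is small, a 1.6-fold lower number from compound 1 to compound 2 (0.21 log units; within the scatter).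

Compound 4, `Nc1nc(N2CCN(C(=O)OCc3ccccc3)CC2)c2nc(-c3ccc(F)cc3)sc2n1`, is not yet measured. The change from compound 3 is benzyloxycarbonyl in place of phenylsulfonyl on an amine nitrogen in a ring. A carbonyl group returns to the ring nitrogen, as in compounds 1 and 2, so the two large steps above are the ones that bear on this change, now read in the reverse direction. A large step downward in this assay is therefore expected, an at least 12-fold lower number from compound 3 to compound 4 (1.09 log units; beyond the scatter). Compound 4 is estimated at 800 nM, with a range from 200 nM to 5000 nM.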

Compound 4, half-maximal inhibitory concentration: 4900 nM
For compound 4 the middle estimate is 6.1-fold (0.79 log units) below the measured one, and the stated range covers the measured number.
By their numbers in this assay, from the lowest: compounds 2 and 1 (each within the scatter of the next); then compound 4. At a limit, above all of these: compound 3.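

Putting a carbonyl back on the ring nitrogen does not by itself return compound 4 to the numbers of compounds 1 and 2, as a 16-fold higher number from compound 2 to compound 4 (1.21 log units; beyond the scatter) and a 10-fold higher number from compound 1 to compound 4 (1.00 log units; beyond the scatter) show. The group on the carbonyl carbon therefore counts at this position, which the earlier pair had not revealed, since its own step, a 1.6-fold lower number from compound 1 to compound 2 (0.21 log units; within the scatter), gave no sign of it, and compound 4 is the one that goes against the idea that any carbonyl group here serves equally well. Against phenylsulfonyl, the change to benzyloxycarbonyl can only be bounded, with an at least 2.0-fold lower number from compound 3 to compound 4 (0.30 log units; that floor lies within the scatter), so it does not establish a difference between the two groups. Compound 3 still has a limit of the assay and not a number: the limit of > 10000 nM in this assay, at which 1 of the 4 values shown sits.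

Going by these compounds, whether the higher number of compound 4 goes with the oxygen attached to the carbonyl carbon or with the benzyl part remains open, and a benzylamino or an ethoxy group on that carbon would separate the two. On these data alone, how far compound 3 actually lies from compound 4 also stays unknown.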